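Adding a Third Double Bond to a Long Side Chain

The source may report more compounds than this note shows. Statements on the series, on what has been measured and on what is new or still open speak of the compounds shown alone.

Compound 2, `CCCCC/C=C\C/C=C\CCCCCCCc1cc(=O)c2c(O)c(C)c(OCOC)c(C)c2o1`, carries a deca-1,4-dien-1-yl chain on the shared core. In a functional assay on MCF7 cells (Homo sapiens) for antiproliferative activity, read by MTT assay (on this read-out higher numbers stand for weaker inhibition and lower numbers for stronger inhibition), compound 2 gives only a limit, > 84100 nM. Its saturated relative, compound 1, `CCCCCCCCCCCCCCCc1cc(=O)c2c(O)c(C)c(OCOC)c(C)c2o1`, likewise gives only a limit in this assay, > 67200 nM. The step that the two limits leave unreadable from compound 1 to compound 2 cannot be read because both values sit at limits, as shown by the limit of > 67200 nM in this assay, at which 1 of the 2 values shown sits, and (the limit of > 84100 nM in this assay, at which 1 of the 2 values shown sits); neither compound showed inhibition within the tested range.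

Compound 3, `CC/C=C\C/C=C\C/C=C\CCCCCCCc1cc(=O)c2c(O)c(C)c(OCOC)c(C)c2o1`, differs from compound 2 in one place: but-1-en-1-yl in place of butyl on a saturated chain carbon bound to a double-bonded chain carbon. Going by the values given here, the only measured step that bears on this change is the unreadable one from compound 1 to compound 2, which introduced two double bonds into the chain without any readable effect. No direction or size can therefore be taken from the data for the third double bond, and compound 3 is expected to behave like its two relatives.

Compound 3 is accordingly expected to give about 90000 nM in this assay, within 30000 nM to 300000 nM, most likely again reported as a limit. The step that the limit leaves unreadable from compound 2 to compound 3 is thus expected to be no change beyond the scatter.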

Compound 3, half-maximal inhibitory concentration: > 84100 nM
Compound 3: no number, only a limit; the forecaster's own chance of this, stated with the estimate: 80%; the middle value does not contradict the limit.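

In this assay compound 3 gives only a limit, as do compound 1 and compound 2, so no step among these three compounds can be read. The compounds shown leave open whether adding double bonds to the long side chain changes antiproliferative activity at all, and in which direction.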